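Dropping a Methyl from a Compound at the Assay Limit

A few compounds are considered here, and "the series" means these few. Any claim that something is new, unique, unknown or untested is made for them only; others in the source may bear on it.

Compound 1 `Cc1ccc2oc(CSc3nc4nc(C)cc(C)n4n3)cc(=O)c2c1`: > 25000 nM
Compound 2 `Cc1ccc2oc(CSc3nc(C)cc(C)n3)cc(=O)c2c1`: > 25000 nM

Of the compounds shown here, two have been measured in a functional assay on MCF7 cells (Homo sapiens) for cytotoxicity, read by MTT assay, with a stated time of 72 h; on this read-out higher numbers stand for weaker inhibition and lower numbers for stronger inhibition. For compound 1 the result is a limit of the assay rather than a number, > 25000 nM. For compound 2 the result is likewise a limit, > 25000 nM. Compound 1 therefore stands at the edge of what the assay can report, and the limit of > 25000 nM in this assay, at which 2 of the 2 values shown sit, shows that every measured value sits there.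

Compound 3 `Cc1cc(C)n2nc(SCc3cc(=O)c4ccccc4o3)nc2n1` has not yet been measured. It differs from compound 1 in one place: hydrogen in place of methyl on an aromatic carbon. Among the measured compounds shown here, no measured pair shows this change, so there is no measured step to lean on. Because compound 1 sits at the limit of > 25000 nM in this assay, at which 2 of the 2 values shown sit, the loss of a single methyl is not expected to move the result by more than the usual scatter, and a limit is again the most likely outcome. The estimate for compound 3 is 30000 nM, within 10000 nM to 100000 nM. This corresponds to an expected step that the limit leaves unreadable from compound 1 to compound 3, essentially none beyond the scatter.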

Compound 3, half-maximal inhibitory concentration: > 25000 nM
Compound 3 ended at the assay's limit (the forecaster's own chance of this, stated with the estimate: 80%); the middle value does not contradict the limit.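

Compound 1 and compound 3 both end at a limit of the assay rather than at a number, so no step can be read between them: the limit of > 25000 nM in this assay, at which 3 of the 3 values shown sit.

The compounds shown leave open whether the methyl has any effect in this assay, since none of them gives a number there.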